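One ring swap, measured once, expected to repeat

The source may hold more compounds than are shown below. What is called first, only, known or untested is meant among the compounds shown, and "the series" means these compounds.

Of the compounds shown here, three have been measured in an ADME assay on HepG2 cells (Homo sapiens) for inhibition, read by fluorescence and resazurin assay, with a stated time of 72 h; a higher number here means a weaker inhibitor, a lower number a stronger inhibitor.

Compound 1, `CN1CCN(c2ccc(Nc3nccc(Nc4ccc5nc[nH]c5c4)n3)cc2)CC1`, gives a limit of the assay: > 25000 nM.
Compound 2, `CN1CCN(c2cccc(Nc3nccc(Nc4ccc5cn[nH]c5c4)n3)c2)CC1`, gives 6700 nM.
Compound 3, `CN1CCN(c2ccc(Nc3nccc(Nc4ccc5cn[nH]c5c4)n3)cc2)CC1`, gives 7000 nM.

Compound 2 and compound 3 have the same atoms joined differently; how their two cores differ is not broken down here. In this assay their values lie within the scatter of each other. Among the compounds with values here, the one measured step is 1H-benzimidazol-6-yl in place of 1H-indazol-6-yl on a nitrogen on an aromatic ring, which carries an at least 3.5-fold higher number from compound 3 to compound 1 (0.55 log units; beyond the scatter). Because compound 1 sits at the limit of > 25000 nM in this assay, at which 1 of the 3 values shown sits, the step is known only as a bound.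

Compound 4, `CN1CCN(c2cccc(Nc3nccc(Nc4ccc5nc[nH]c5c4)n3)c2)CC1`, is not yet measured. It stands to compound 2 as compound 1 stands to compound 3: 1H-benzimidazol-6-yl in place of 1H-indazol-6-yl on a nitrogen on an aromatic ring, the same change at the same place. Because of an at least 3.5-fold higher number from compound 3 to compound 1 (0.55 log units; beyond the scatter), a step of at least similar size is expected in this assay, namely a 4.5-fold higher number from compound 2 to compound 4 (0.65 log units; beyond the scatter). Compound 4 is therefore estimated to come out near 30000 nM, between 15000 nM and 80000 nM, quite possibly again as a limit.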

Compound 4, half-maximal inhibitory concentration: 11000 nM
Compound 4: the middle estimate sits 2.7-fold (0.44 log units) above what was measured; measured number below the stated range.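

In this assay, within the data shown here, 1H-benzimidazol-6-yl in place of 1H-indazol-6-yl on the core of compound 2 gives a 1.6-fold higher number from compound 2 to compound 4 (0.22 log units; within the scatter), so on this core the change leaves no step that can be told from the scatter. On the core of compound 3 the same change did give a step beyond the scatter, yet the two steps cannot be called different: the same change on two cores in this assay, an at least 3.5-fold higher number (0.55 log units; beyond the scatter) from compound 3 to compound 1 and a 1.6-fold higher number (0.22 log units; within the scatter) from compound 2 to compound 4; the limit leaves it open whether they differ. Compound 1 gives > 25000 nM, which is a limit of the assay and not a number, so the data show neither that the size of the step carries from one core to the other nor that it fails to.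

The compounds shown leave open how large the step on the core of compound 3 really is, and whether a third core would follow either result. They also leave open whether the change would behave alike with a morpholine or a carboxylic acid on the shared core.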